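The source may hold more compounds than are shown below. What is called first, only, known or untested is meant among the compounds shown, and "the series" means these compounds.

Compound 1 `CCN(C/C=C/C#CC(C)(C)C)Cc1cccc(OCCNS(=O)(=O)c2cccs2)c1` gives 450 nM in a functional assay on HepG2 cells for inhibition of squalene monooxygenase (Homo sapiens); on this read-out lower numbers stand for stronger inhibition and higher numbers for weaker inhibition.
Compound 2 `CCN(C/C=C/C#CC(C)(C)C)Cc1cccc(OCCN(C)S(=O)(=O)c2ccc(C#N)cc2)c1` gives 200 nM in this assay.

Of the two numbers measured, compound 2 holds the lowest, with compound 1 standing beyond the scatter from it. Compound 3 `CCN(C/C=C/C#CC(C)(C)C)Cc1cccc(OCCN(C)S(=O)(=O)c2nccs2)c1` has not been measured; it differs from compound 2 by 1,3-thiazol-2-yl in place of 4-cyanophenyl on a sulfonyl sulfur. Going by the values given here, no measured pair shows this change, so the step is open. Compound 3 is expected to give a slightly higher number than compound 2, a step near the scatter, estimated as a 1.6-fold higher number from compound 2 to compound 3 (0.20 log units; within the scatter). The estimate for compound 3 in this assay is 320 nM, with a range from 120 nM to 850 nM.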

Compound 3, half-maximal inhibitory concentration: 170 nM
Estimate against measurement, compound 3: 1.9-fold (0.27 log units) above, and the stated range covers the measured number.
By their numbers in this assay, from the lowest: compounds 3 and 2 (each within the scatter of the next); then compound 1.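

In this assay, 1,3-thiazol-2-yl in place of 4-cyanophenyl on the sulfonyl sulfur gives a 1.2-fold lower number from compound 2 to compound 3 (0.07 log units; within the scatter), so this position accepts either a five-membered or a six-membered aromatic ring without a change that can be read. The wider change at the end of the chain gives a 2.6-fold lower number from compound 1 to compound 3 (0.42 log units; beyond the scatter). Nothing available explains either step. Open, going by these compounds, is how a plain phenyl, a 2-pyridyl or a small alkyl such as ethyl on the sulfonyl sulfur would read. Also open, on these data alone, is what the methyl on the sulfonamide nitrogen contributes alone.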